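A few compounds are considered here, and "the series" means these few. Any claim that something is new, unique, unknown or untested is made for them only; others in the source may bear on it.

The series rests on a shared core carrying a chloro group, with a benzyl arm that bears a chloromethyl group, and it was examined in a functional assay on MOLT-4 cells (Homo sapiens) for cytotoxicity, read by sulforhodamine B assay, with a stated time of 48 h; a higher number here means a weaker inhibitor of growth, a lower number a stronger inhibitor of growth. Compound 1, `ClCc1ccc(Cn2cnc3c(Cl)ncnc32)cc1`, gives 4780 nM in this assay. Compound 2, `Nc1nc(Cl)c2ncn(Cc3ccc(CCl)cc3)c2n1`, differs from compound 1 by amino in place of hydrogen on an aromatic carbon; in this assay compound 2 gives 2950 nM, and the step is a 1.6-fold lower number from compound 1 to compound 2 (0.21 log units; within the scatter). Compound 3, `ClCc1ccccc1Cn1cnc2c(Cl)ncnc21`, has the same atoms as compound 1 joined differently, and how its core differs from that of compound 1 is not broken down here; in this assay compound 3 gives 1580 nM, which lies beyond the scatter from the number for compound 1, while it stays within the scatter of the number for compound 2.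

Compound 4, `Nc1nc(Cl)c2ncn(Cc3ccccc3CCl)c2n1`, is still to be measured in this assay. It differs from compound 3 by amino in place of hydrogen on an aromatic carbon, and the place of the change is described in the same words as for the step from compound 1 to compound 2, so it is the same change made on the core of compound 3. Because the measured example of this change is a 1.6-fold lower number from compound 1 to compound 2 (0.21 log units; within the scatter), compound 4 is expected to show a step of a 1.6-fold lower number from compound 3 to compound 4 (0.20 log units; within the scatter), small enough to fall within the scatter. On that basis compound 4 is estimated to give 1000 nM in this assay, with a range from 400 nM to 2500 nM.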

Compound 4, concentration for 50% growth inhibition: 5130 nM
The estimate for compound 4 lay 5.1-fold (0.71 log units) below the measured number, and the stated range ends below it.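

On the core of compound 3, amino in place of hydrogen on an aromatic carbon, between two ring nitrogen atoms, gives a 3.2-fold higher number from compound 3 to compound 4 (0.51 log units; beyond the scatter) in this assay. Set beside the earlier example, the same change does not carry over from one core to the other with the same outcome: the same change on two cores in this assay, a 1.6-fold lower number (0.21 log units; within the scatter) from compound 1 to compound 2 and a 3.2-fold higher number (0.51 log units; beyond the scatter) from compound 3 to compound 4, 5.3-fold (0.72 log units) apart, beyond the scatter of two such steps

For the compounds shown here, this shows that, across these two pairs, the step seen on the core of compound 1 is no safe guide to the step on the core of compound 3, even though the two cores hold the same atoms joined differently, but it does not show why the steps part, nor does it give a rule for any further core, since it rests on only two pairs in a single cell line.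

Going by these compounds, it remains open whether a methylamino group or a hydroxyl group in the same place would follow the pair of compound 1 and compound 2 or the pair of compound 3 and compound 4. On these data alone, it is equally open whether the gap between the two steps would persist with a bromomethyl group or a longer chain such as chloroethyl in place of the chloromethyl group on the benzyl arm.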